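Para-substituent swap at the aroyl ring of the series

This account rests on a few compounds, and the source may have more. Where it says the series, first, only, none or still open, it means among the compounds named here.

Among the compounds with values here, compound 2 `CCOC(=O)[C@@H]1/C(=C/C(=O)c2ccc(F)cc2)N=C(C)/C(=C(/O)OCC)[C@H]1c1ccccc1C(F)(F)F` gives 117 nM in an assay on brain for binding affinity to Voltage-gated L-type calcium channel (Rattus norvegicus) (on this read-out lower numbers stand for stronger inhibition and higher numbers for weaker inhibition), the higher of the two numbers measured so far; the only neighbour is compound 1 `CCOC(=O)[C@@H]1/C(=C/C(=O)c2ccncc2)N=C(C)/C(=C(/O)OCC)[C@H]1c1ccccc1C(F)(F)F`, which gives 25.5 nM, and the step of a 4.6-fold higher number from compound 1 to compound 2 (0.66 log units; beyond the scatter) separates them. Compound 3 `CCOC(=O)[C@@H]1/C(=C/C(=O)c2ccc(C)cc2)N=C(C)/C(=C(/O)OCC)[C@H]1c1ccccc1C(F)(F)F` is not yet measured; it differs from compound 2 by methyl in place of fluoro on an aromatic carbon, the change reading 4-fluorophenyl to 4-methylphenyl on the carbonyl. Within the data shown here, no measured step bears directly on this change: the single step on record, from compound 1 to compound 2, exchanges the whole ring on the carbonyl carbon rather than a substituent on it, so it gives no direction for a fluoro-to-methyl swap. Among the measured compounds shown here, with only one step of modest size and none of the same kind, the expectation for compound 3 is a step close to none beyond the scatter, a 1.0-fold higher number from compound 2 to compound 3 (0.01 log units; within the scatter). Compound 3 is therefore estimated at 120 nM, with a range from 40 nM to 400 nM, the width reflecting the absence of any comparable step.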

Compound 3, half-maximal inhibitory concentration: 414 nM
The estimate for compound 3 lay 3.5-fold (0.54 log units) below the measured number, and the stated range ends below it.
By their numbers in this assay, from the lowest: compound 1; then compound 2; then compound 3.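

In this assay the substituent on the aromatic carbon para to a large group matters on its own, not only the identity of the whole ring: methyl in place of fluoro, one heavy atom for one heavy atom, gives a 3.5-fold higher number from compound 2 to compound 3 (0.55 log units; beyond the scatter), a step graded modest, like the earlier ring exchange. Across the series, the exchange of pyridin-4-yl for 4-methylphenyl gives a 16-fold higher number from compound 1 to compound 3 (1.21 log units; beyond the scatter), so the three compounds now fall in a clear order from pyridin-4-yl through 4-fluorophenyl to 4-methylphenyl, with every step beyond the scatter and no compound shown going against that order. Nothing available explains why the fluoro and methyl compounds differ in this way.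

The compounds shown leave open where other groups at the same place, such as chloro, methoxy, an amine or a carboxylic acid, would fall in this order. They also leave open whether the fluoro-to-methyl step keeps its size when the trifluoromethyl group or the ethyl esters of the shared core are exchanged.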